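Cytotoxicity limits: 3-cyanophenyl to 3-methoxyphenyl

The compounds below may be only part of what the source reports. "The series", "measured", "known", "first", "only" and "open" are said of these compounds alone.

- compound 1 `COc1cc2nc([S+]([O-])CC(=O)Nc3ccccc3C#N)nc(Nc3c(Cl)cc(/C=C/C#N)cc3Cl)c2cc1OC` gives the limit > 206000 nM
- compound 2 `COc1cc2nc([S+]([O-])CC(=O)Nc3cccc(C#N)c3)nc(Nc3c(Cl)cc(/C=C/C#N)cc3Cl)c2cc1OC` gives the limit >= 70300 nM

In an ADME assay on MT4 cells (Homo sapiens) for cytotoxicity, read by MTT assay, with a stated time of 5 days (a higher number here means that more compound is tolerated, a lower number that less compound is tolerated), compound 2 stands at the limit >= 70300 nM and carries no number. Compound 3 `COc1cccc(NC(=O)C[S+]([O-])c2nc(Nc3c(Cl)cc(/C=C/C#N)cc3Cl)c3cc(OC)c(OC)cc3n2)c1` follows from compound 2 by one change methoxy in place of cyano on an aromatic carbon in which methoxy stands in place of cyano on an aromatic carbon. Among the compounds with values here, the only measured step is a step that the two limits leave unreadable from compound 1 to compound 2 and it concerns a different change, so no size carries over. No step beyond the scatter is therefore expected in this assay in either direction. The expectation rests on compound 2 with its limit >= 70300 nM and a further limit is likely for compound 3. The estimated step is a step that the limit leaves unreadable from compound 2 to compound 3 and has no firm direction. For compound 3 the estimate is 100000 nM with an expected range from 30000 nM to 250000 nM if a number is reported at all.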

Compound 3, half-maximal cytotoxic concentration: >= 167000 nM
Compound 3: a limit, no number (the forecaster's own chance of this, stated with the estimate: 70%); middle value at least 1.6-fold (0.22 log units) from the limit.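

In this assay compound 3 gives >= 167000 nM, which is a limit and not a number. Within the data shown here, compound 1, compound 2 and compound 3 all carry limits, so no step among them can be read. From the compounds shown here alone, whether 2-cyanophenyl, 3-cyanophenyl and 3-methoxyphenyl differ at all in this assay stays open.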